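Swapping the amine at the thiocarbonyl carbon of compound 3

This account rests on a few compounds, and the source may have more. Where it says the series, first, only, none or still open, it means among the compounds named here.

Compound 1 `O=c1c(SC(=S)N2CCCC2)coc2ccc(Cl)cc12`: 26000 nM
Compound 2 `O=c1cc(CSC(=S)N2CCCCC2)oc2ccccc12`: 12000 nM
Compound 3 `O=c1c(Cl)c(CSC(=S)N2CCCCC2)oc2ccccc12`: 940 nM

In a functional assay on HEp-2 cells (Homo sapiens) for antiproliferative activity, read by MTT assay, with a stated time of 72 h (a lower number here means a stronger inhibitor, a higher number a weaker inhibitor), compound 3 gives the lowest number of the three. Within the data shown here, the only single-point step measured, a 13-fold lower number from compound 2 to compound 3 (1.11 log units; beyond the scatter), concerns the chloro group; compound 1 differs from compound 3 in more than one place and cannot be read as a step. Compound 4 `CC(C)N(C(=S)SCc1oc2ccccc2c(=O)c1Cl)C(C)C` carries the change (diisopropylamino in place of piperidin-1-yl on a thiocarbonyl carbon). Among the measured compounds shown here, no measured step bears on an exchange of the amine, so for compound 4 the expected step in this assay is a 1.3-fold higher number from compound 3 to compound 4 (0.11 log units; within the scatter), not beyond the scatter, with wide uncertainty. For compound 4 the estimate in this assay is 1200 nM, within 350 nM to 4500 nM.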

Compound 4, half-maximal inhibitory concentration: 20000 nM
Beside the measured number, compound 4's estimate is 17-fold (1.22 log units) below it; the measured number lies above the stated range.
By their numbers in this assay, from the lowest: compound 3; then compounds 2, 4 and 1 (each within the scatter of the next, the first and the last beyond it).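

In this assay, the amine at the thiocarbonyl carbon turns out to matter: replacing piperidin-1-yl with diisopropylamino gives a 21-fold higher number from compound 3 to compound 4 (1.33 log units; beyond the scatter). Among these compounds, the earlier compounds showed only that the chloro group changes the number; this is the first measured sign that the amine does too, with the chloro group present in both compounds. Nothing available explains this step.

Going by these compounds, whether the loss goes with the open ring or with the branched chains stays open, since only two amines are compared on this core. A diethylamino or morpholin-4-yl group on the same carbon would bear on that question.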